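This account rests on a few compounds, and the source may have more. Where it says the series, first, only, none or still open, it means among the compounds named here.

Compound 1 `N#Cc1ccc2c(F)cc(Oc3ccccc3OCCn3ccc(=O)[nH]c3=O)c(Cl)c2c1` and compound 2 `Cc1c(Oc2ccccc2OCCn2ccc(=O)[nH]c2=O)cc(F)c2ccc(C#N)cc12` share one core and differ at a single aromatic carbon. In a toxicity assay on MT2 cells (Homo sapiens) for cytotoxicity, read by MTT assay (a lower number here means that less compound is tolerated, a higher number that more compound is tolerated), compound 1 gives > 100000 nM, a limit of the assay and not a number. In this assay compound 2 gives > 100000 nM, likewise a limit. The step that the two limits leave unreadable from compound 1 to compound 2 therefore cannot be sized; both values rest at the limit of > 100000 nM in this assay, at which 2 of the 2 values shown sit. Compound 2 thus stands at the limit, with no measured number in this assay to place it against.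

Compound 3 `Cc1c(Oc2ccccc2OCCn2ccc(=O)[nH]c2=O)cc(C(C)C)c2ccc(C#N)cc12` differs from compound 2 as isopropyl in place of fluoro on an aromatic carbon. For the measured compounds named here, the only measured step, from compound 1 to compound 2, offers no readable size, so no step bears on this change with a usable magnitude. The expectation for compound 3 in this assay rests on the two limits alone. The expected step is a number no higher from compound 2 to compound 3 (the limit leaves the size open). Compound 3 is estimated at 100000 nM, between 50000 nM and 300000 nM, and is most likely to be reported again as a limit.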

Compound 3, half-maximal cytotoxic concentration: 9000 nM
The estimate for compound 3 lay 11-fold (1.05 log units) above the measured number; measured number below the stated range.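

In this assay, for the compounds shown here, the aromatic carbon para to a methyl group is the first place where a change gives a readable step: isopropyl in place of fluoro gives an at least 11-fold lower number from compound 2 to compound 3 (1.04 log units; beyond the scatter). Compound 3 thus shows that tolerance in this assay depends on what this carbon carries, whereas the step from chloro to methyl at the other aromatic carbon cannot be read. The size of the new step is only a bound, since compound 2 carries a limit and not a number: the limit of > 100000 nM in this assay, at which 2 of the 3 values shown sit.

From the compounds shown here alone, how an ethyl group, a methoxy group or an amine at this carbon would read in this assay remains open. Also open, going by these compounds, is whether isopropyl here would give a comparable step with chloro in place of the methyl group.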